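The source may report more compounds than this note shows. Statements on the series, on what has been measured and on what is new or still open speak of the compounds shown alone.

In a functional assay on DLD-1 cells (Homo sapiens) for antiproliferative activity, read by CellTiter-Glo, with a stated time of 72 h (a lower number here means a stronger inhibitor, a higher number a weaker inhibitor), compound 1 `Cc1noc(C)c1S(=O)(=O)N1CCC(N2CCC(C)CC2)CC1` does not yield a number: the reading is the limit > 5000 nM, so compound 1 sits at the limit of > 5000 nM in this assay, at which 1 of the 2 values shown sits, and its true potency is only known to lie beyond that boundary. Compound 2 `COc1cc(C)c(S(=O)(=O)N2CCC(N3CCC(C)CC3)CC2)cc1C(C)C` is a second member of the same series, and in this assay compound 2 gives 3 nM. For the measured compounds named here, no pair of compounds differing in a single place has been measured, so no step size is known yet.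

Compound 3 `CC1CCN(C2CCN(S(=O)(=O)c3cccc(N)c3)CC2)CC1` is the next compound to be tested. The change from compound 1 is 3-aminophenyl in place of 3,5-dimethyl-1,2-oxazol-4-yl on a sulfonyl sulfur. Going by the values given here, compound 2, the one potent member, also carries a six-membered aromatic ring on its sulfonyl sulfur, whereas compound 1 carries the five-membered one. On that basis a gain is expected for compound 3, though a cautious one, since the step of an at least 3.3-fold lower number from compound 1 to compound 3 (0.52 log units; beyond the scatter) is estimated from a limit rather than a number. Compound 3 is expected to give 1500 nM, within 200 nM to 10000 nM.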

Compound 3, half-maximal inhibitory concentration: 3400 nM
Beside the measured number, compound 3's estimate is 2.3-fold (0.36 log units) below it; the range from low to high includes it.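

The change on the sulfonyl sulfur gives an at least 1.4-fold lower number from compound 1 to compound 3 (0.16 log units; that floor lies within the scatter), so a real gain from 3-aminophenyl over 3,5-dimethyl-1,2-oxazol-4-yl is not established. The reading for compound 1 is a limit and not a number: the limit of > 5000 nM in this assay, at which 1 of the 3 values shown sits.

In this assay compound 3 gives 3400 nM and compound 2 gives 3 nM, which shows that a six-membered aromatic ring on the sulfonyl sulfur is not enough by itself to reach the low number of compound 2.

The compounds shown leave open which of the substituents on the ring of compound 2 accounts for that low number. As far as these compounds go, it also remains open how a plain phenyl ring, or a phenyl ring carrying only a methoxy group or only an isopropyl group, would read in this assay.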